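Adding a diethylamino chain to a weak compound

The source may report more compounds than this note shows. Statements on the series, on what has been measured and on what is new or still open speak of the compounds shown alone.

Measured in a functional assay on HeLa cells (Homo sapiens) for antiproliferative activity, read by MTT assay, with a stated time of 48 h; a lower number here means a stronger inhibitor, a higher number a weaker inhibitor:
- Compound 1 `Cn1c(N)c(-c2nc3ccccc3[nH]2)c2nc(C#N)c(C#N)nc21`: > 50000 nM
- Compound 2 `CN(C)CCn1c(N)c(-c2nc3ccccc3[nH]2)c2nc(C#N)c(C#N)nc21`: 8880 nM
- Compound 3 `CCN(CC)CCCn1c(N)c(-c2nc3ccccc3[nH]2)c2nc(C#N)c(C#N)nc21`: 3150 nM

In this assay compound 1 gives only a limit, > 50000 nM, and not a number.

Compound 4 `CCN(CC)CCCCn1c(-c2c(N)n(C)c3nc(C#N)c(C#N)nc23)nc2ccccc21` differs from compound 1 as follows: 4-(diethylamino)butyl in place of hydrogen on an aromatic nitrogen. Among the compounds with values here, three measured steps bear on this change: an at least 5.6-fold lower number from compound 1 to compound 2 (0.75 log units; beyond the scatter), an at least 15-fold lower number from compound 1 to compound 3 (1.20 log units; beyond the scatter) and a 2.8-fold lower number from compound 2 to compound 3 (0.45 log units; beyond the scatter). Those steps changed a saturated chain carbon, whereas compound 4 carries its 4-(diethylamino)butyl on an aromatic nitrogen of a five-membered aromatic ring, so they are only a loose guide. A clear move towards a lower number is still expected, and the estimated step is an at least 10-fold lower number from compound 1 to compound 4 (1.00 log units; beyond the scatter). For compound 4 the estimated value is 5000 nM, with an expected range of 1200 nM to 30000 nM.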

Compound 4, half-maximal inhibitory concentration: 11800 nM
Compound 4: middle estimate off by 2.4-fold (0.37 log units), on the low side, and the stated range covers the measured number.
By their numbers in this assay, from the lowest: compound 3; then compounds 2 and 4 (each within the scatter of the next). At a limit, above all of these: compound 1.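

In this assay, within the data shown here, a 4-(diethylamino)butyl chain on the aromatic nitrogen of the five-membered ring also lowers the number, an at least 4.2-fold lower number from compound 1 to compound 4 (0.62 log units; beyond the scatter), so an amine chain can sit at this second site on the shared core, not only where the earlier compounds carry theirs. Compound 1 stands at a limit and not at a number, so this step has no known upper end: the limit of > 50000 nM in this assay, at which 1 of the 4 values shown sits.

The compounds shown leave open whether the amine matters at this nitrogen, which a plain butyl chain would test. On these data alone, how a shorter chain, such as 2-(diethylamino)ethyl, would behave here also remains open.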